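The source may report more compounds than this note shows. Statements on the series, on what has been measured and on what is new or still open speak of the compounds shown alone.

Compound 1 `CN(C(=O)C[C@@H](N)CCCCN)C1CN=C(Nc2ncccn2)NC1=O` gives, in a functional assay for inhibition, with Oryctolagus cuniculus as the target (on this read-out lower numbers stand for stronger inhibition and higher numbers for weaker inhibition), 380 nM. Compound 2 `CN(C(=O)C[C@@H](N)CCCCN)C1CN=C(Nc2ccccn2)NC1=O` gives, in this assay, 200 nM.

Going by the values given here, of these two numbers, the one for compound 2 is the smaller, yet the step of a 1.9-fold lower number from compound 1 to compound 2 (0.28 log units; within the scatter) falls within the scatter, so the two compounds cannot be told apart on this read-out. Compound 3 `CN(C(=O)C[C@@H](N)CCCCN)C1CN=C(Nc2cnccn2)NC1=O` has not yet been measured. It differs from compound 2 by pyrazin-2-yl in place of pyridin-2-yl on an amine nitrogen. Among the compounds with values here, the only measured step that bears on this exchange is a 1.9-fold lower number from compound 1 to compound 2 (0.28 log units; within the scatter), in which one six-membered aromatic ring with two hetero atoms gave way to one with a single hetero atom without a change beyond the scatter. Returning to a ring with two hetero atoms is therefore expected to move the number little, and the step of a 1.5-fold higher number from compound 2 to compound 3 (0.18 log units; within the scatter) is estimated to stay within the scatter. For compound 3 the expected result in this assay is 300 nM, with a range from 120 nM to 750 nM.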

Compound 3, half-maximal inhibitory concentration: < 100 nM
Compound 3 ended at the assay's limit (the forecaster's own chance of this, stated with the estimate: 3%); middle value at least 3.0-fold (0.47 log units) away from the limit.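

The value for compound 3 is a limit of the assay and not a number: the limit of < 100 nM in this assay, at which 1 of the 3 values shown sits.

The two rings with 2 hetero atoms are not interchangeable on this amine nitrogen: pyrazin-2-yl in place of pyrimidin-2-yl gives an at least 3.8-fold lower number from compound 1 to compound 3 (0.57 log units; beyond the scatter), so the count of hetero atoms in the ring does not by itself set the number in this assay. Against pyridin-2-yl the change reads an at least 2.0-fold lower number from compound 2 to compound 3 (0.30 log units; that floor lies within the scatter); only a floor is known for this step, and it does not clear the scatter, so this comparison stays unsettled.

How far the true value of compound 3 lies past the limit remains unknown, and nothing shown explains the gain. Also open, going by these compounds, is how a phenyl ring or a pyridazin-3-yl ring on the same amine nitrogen would compare.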